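Adding a Second Fluorine: Expected Cytotoxicity of Compound 3

The source may report more compounds than this note shows. Statements on the series, on what has been measured and on what is new or still open speak of the compounds shown alone.

Measured so far:
- Compound 1, `Cc1cc(-c2ccc(F)cc2)cc(C)c1Nc1ccnc(Nc2ccc(C#N)cc2)n1`, gives 4170 nM in an ADME assay on MT4 cells (Homo sapiens) for cytotoxicity, read by MTT assay, with a stated time of 4 days; on this read-out lower numbers stand for higher toxicity in this test and higher numbers for lower toxicity in this test.
- Compound 2, `Cc1cc(-c2cccc(F)c2)cc(C)c1Nc1ccnc(Nc2ccc(C#N)cc2)n1`, gives 4120 nM in this assay.
- Compound 3, `Cc1cc(-c2cc(F)cc(F)c2)cc(C)c1Nc1ccnc(Nc2ccc(C#N)cc2)n1`, is not yet measured.

For the measured compounds named here, compound 2 stands at the lower of the two numbers so far, but the only measured step, a 1.0-fold lower number from compound 1 to compound 2 (0.01 log units; within the scatter), is within the scatter, so the two compounds cannot be told apart on this read-out. That step moved a single fluoro group from one place on the outer ring to another and left the cytotoxicity unchanged.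

The change toward compound 3 is fluoro in place of hydrogen on an aromatic carbon. In plain words, the outer ring that already carries one fluoro gains a second one, giving a 3,5-difluorophenyl group.

Going by the values given here, the one measured step bears on this only loosely: it shows that where a single fluoro sits makes no difference to the number, but nothing has yet been measured for a second fluoro. With no sign of sensitivity to fluorine in the data, the expected step is a 1.2-fold lower number from compound 2 to compound 3 (0.07 log units; within the scatter), that is, a change that stays within the scatter. The estimate for compound 3 in this assay is therefore 3500 nM, with a likely range from 1500 nM to 8000 nM.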

Compound 3, half-maximal cytotoxic concentration: 3910 nM
Compound 3: the middle estimate sits 1.1-fold (0.05 log units) below what was measured, and the stated range covers the measured number.
By their numbers in this assay, from the lowest: compounds 3, 2 and 1 (each within the scatter of the next).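

In this assay, the outer ring now carries a second fluoro, meta to the first, and the result is a 1.1-fold lower number from compound 2 to compound 3 (0.02 log units; within the scatter), so adding this atom produces no difference that the read-out can resolve. Comparing the 3,5-difluorophenyl group with the 4-fluorophenyl group gives a 1.1-fold lower number from compound 1 to compound 3 (0.03 log units; within the scatter), so these two compounds also cannot be told apart, even though they differ in both the number and the placement of their fluoro groups. Taken together, the three compounds show that, among the fluoro patterns tested here, the cytotoxicity number stays within the usual scatter, and no separate measurement is available to explain this.

All three compounds carry only fluoro on the outer ring, so they leave open whether a methoxy group, an amine or a carboxylic acid at the same place would give a number distinguishable from theirs. They also leave open where a plain phenyl ring with no fluoro would fall, and whether a third fluoro would still stay within the scatter of these compounds.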